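This account rests on a few compounds, and the source may have more. Where it says the series, first, only, none or still open, it means among the compounds named here.

Compound 1 `NC1=NC2(CCOCC2)N(OCCCOc2ccccc2Cl)C(N)=N1` gives 70 nM in a functional assay on HCT-116 cells (Homo sapiens) for antiproliferative activity, read by MTT assay, with a stated time of 72 h; on this read-out higher numbers stand for weaker inhibition and lower numbers for stronger inhibition.
Compound 2 `NC1=NC2(CCOCC2)N(OCCCOc2cccc(Br)c2)C(N)=N1` gives 40 nM in this assay.
Compound 3 `NC1=NC2(CCSCC2)N(OCCCOc2ccccc2Cl)C(N)=N1` gives 1 nM in this assay.

Compounds 1 and 2 share a core and differ only by 3-bromophenyl in place of 2-chlorophenyl on an oxygen on a saturated carbon. That change made a 1.8-fold lower number from compound 1 to compound 2 (0.24 log units; within the scatter). Compound 3 rests on a different core; the difference between the two cores is not broken down here, but compound 3 stands far below compounds 1 and 2 in this assay. Compound 4 `NC1=NC2(CCSCC2)N(OCCCOc2cccc(Br)c2)C(N)=N1` is the not yet measured partner of compound 3, carrying the same change, (3-bromophenyl in place of 2-chlorophenyl on an oxygen on a saturated carbon), at the same place. Because the earlier step of a 1.8-fold lower number from compound 1 to compound 2 (0.24 log units; within the scatter) stayed within the scatter, the step from compound 3 to compound 4 is expected to be about a 1.4-fold lower number from compound 3 to compound 4 (0.15 log units; within the scatter). Compound 4 is therefore estimated at 0.7 nM in this assay, with a likely range from 0.3 nM to 3 nM.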

Compound 4, half-maximal inhibitory concentration: 1 nM
Compound 4: middle estimate off by 1.4-fold (0.15 log units), on the low side; the measured number falls inside the stated range.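

In this assay, putting 3-bromophenyl in place of 2-chlorophenyl on the core of compound 3 gave no change at the digits printed from compound 3 to compound 4 (within the scatter). Set beside the earlier step on the core of compound 1, the change reads alike on both cores: the same change on two cores in this assay, a 1.8-fold lower number (0.24 log units; within the scatter) from compound 1 to compound 2 and no change at the digits printed (within the scatter) from compound 3 to compound 4, 1.8-fold (0.24 log units) apart, within the scatter of two such steps. This shows only that, across these two pairs, swapping these two groups left the number within the scatter on either core; it does not show that the same would hold on any further core or for any other group.

The compounds shown leave open how an unsubstituted phenyl, an amine or a carboxylic acid would fare in place of these two groups. From the compounds shown here alone, how a longer chain would fare also remains open.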